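The source may hold more compounds than are shown below. What is called first, only, known or untested is meant among the compounds shown, and "the series" means these compounds.

In a functional assay on Huh-7 cells (Homo sapiens) for cytotoxicity, read by MTT assay, with a stated time of 72 h (on this read-out higher numbers stand for lower toxicity in this test and lower numbers for higher toxicity in this test), three compounds have been read: compound 1 (`CCS(=O)(=O)N1CCC2(CC1)OOC1(CCCC1)OO2`), compound 2 (`CCCS(=O)(=O)N1CCC2(CC1)OOC1(CCCCC1)OO2`) and compound 3 (`CCCCS(=O)(=O)N1CCC2(CC1)OOC1(CCCC1)OO2`). Compound 1 gives > 100 ug/mL as a limit. Compound 2 also gives > 100 ug/mL as a limit. Compound 3 gives > 100 ug/mL as a limit. Compound 2 and the others thus stand at the limit of > 100 ug/mL in this assay, at which 3 of the 3 values shown sit, for now. Compound 4 (`Cc1ccc(S(=O)(=O)N2CCC3(CC2)OOC2(CCCCC2)OO3)cc1`) differs from compound 2 by 4-methylphenyl in place of propyl on a sulfonyl sulfur. For the measured compounds named here, the one measured step (a step that the two limits leave unreadable from compound 1 to compound 3) offers no size to carry over, so no shift beyond the scatter is expected. In this assay the estimated step is a number no higher from compound 2 to compound 4 (the limit leaves the size open) and is expected to stay within the scatter. For compound 4 the expected value is 100 ug/mL with an estimated range from 40 ug/mL to 200 ug/mL in this test.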

Compound 4, half-maximal cytotoxic concentration: > 100 ug/mL
Compound 4: a limit, no number; the forecaster's own chance of this, stated with the estimate: 70%; the middle value lies on the limit itself.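

In this assay compound 2 and compound 4 both give limits, and no step can be read between them. The compounds shown leave open whether any of these changes alters the read-out, since all share one place: the limit of > 100 ug/mL in this assay, at which 4 of the 4 values shown sit.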